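Pyrimidinyl amide in place of benzamide on the shared core

The compounds below may be only part of what the source reports. "The series", "measured", "known", "first", "only" and "open" are said of these compounds alone.

Compound 1 `O=C(O)c1ccc2noc(-c3ccc(N4CCCCC4)cc3)c2c1` gives 240 nM in an assay for inhibition of inositol hexakisphosphate kinase 2 (Homo sapiens), read by colorimetric assay, coupled enzyme assay and malachite green, with a stated time of 120 min, in the presence of a further agent that is not named here; on this read-out lower numbers stand for stronger inhibition and higher numbers for weaker inhibition.
Compound 2 `O=C1CCC(C(=O)Nc2ccc(-c3onc4ccc(C(=O)O)cc34)cc2)CN1` gives 2390 nM in this assay.
Compound 3 `O=C(O)c1ccc2noc(-c3ccc(NC(=O)c4ccccc4)cc3)c2c1` gives 580 nM in this assay.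

Compound 3 holds the second highest of the three numbers in this assay: the steps that reach it are a 2.4-fold higher number from compound 1 to compound 3 (0.38 log units; beyond the scatter) and a 4.1-fold lower number from compound 2 to compound 3 (0.61 log units; beyond the scatter). Compound 4 `O=C(O)c1ccc2noc(-c3ccc(NC(=O)c4ccncn4)cc3)c2c1` differs from compound 3 by pyrimidin-4-yl in place of phenyl on a carbonyl carbon. For the measured compounds named here, only the step from compound 2 to compound 3 changes a ring on that same carbonyl carbon, and it was modest, favouring the phenyl over a non-aromatic ring. Going by the values given here, no measured step tests ring nitrogens in an aromatic ring at this place. The step of a 1.5-fold higher number from compound 3 to compound 4 (0.17 log units; within the scatter) is therefore expected to be small, probably toward a higher number. Compound 4 is estimated at 850 nM, within 300 nM to 2500 nM.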

Compound 4, half-maximal inhibitory concentration: 720 nM
The estimate for compound 4 lay 1.2-fold (0.07 log units) above the measured number; the measured number falls inside the stated range.
By their numbers in this assay, from the lowest: compound 1; then compounds 3 and 4 (each within the scatter of the next); then compound 2.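

In this assay, pyrimidin-4-yl and phenyl on this carbonyl carbon cannot be told apart, with a 1.2-fold higher number from compound 3 to compound 4 (0.09 log units; within the scatter), so ring nitrogens in the aromatic ring make no measurable difference here. Compound 4 still keeps the advantage of an aromatic ring over the non-aromatic ring, with a 3.3-fold lower number from compound 2 to compound 4 (0.52 log units; beyond the scatter), but it does not match the piperidin-1-yl group, with a 3.0-fold higher number from compound 1 to compound 4 (0.48 log units; beyond the scatter). Nothing available explains why the two aromatic rings read alike.

Going by these compounds, what a pyridin-2-yl ring or a dimethylamino group would give on this carbonyl carbon remains open. So does whether a tetrazole could stand in for the carboxylic acid on the shared core.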